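One amide substituent exchanged on compound 1

The compounds below may be only part of what the source reports. "The series", "measured", "known", "first", "only" and "open" are said of these compounds alone.

Of the compounds shown here, two have numbers so far. In a functional assay on HepG2 cells (Homo sapiens) for antiproliferative activity, read by MTT assay, with a stated time of 72 h (on this read-out lower numbers stand for stronger inhibition and higher numbers for weaker inhibition), compound 1 `Cc1noc(C)c1-c1nn(Cc2ccc(C(=O)NC3CC(C)(C)N([O])C(C)(C)C3)cc2)c(=O)c2ccccc12` gives 85100 nM and compound 2 `O=C(Nc1ccccc1Cl)c1ccc(Nc2nn(Cc3ccc(C(=O)NC4CCCCC4)cc3)c(=O)c3ccccc23)cc1` gives 82400 nM on the same read-out. These two values lie within the usual scatter of each other, so compound 1 stands level with compound 2 and neither can be ranked ahead.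

Compound 3 `Cc1noc(C)c1-c1nn(Cc2ccc(C(=O)NC3CCCCC3)cc2)c(=O)c2ccccc12` keeps the core of compound 1 and exchanges one group, with cyclohexyl entering. The change is a group of 6 heavy atoms (6 carbon; one six-membered non-aromatic ring of carbon only) in place of a group of 11 heavy atoms (9 carbon, 1 nitrogen, 1 oxygen; one six-membered non-aromatic ring with 1 hetero atom), on an amide-type nitrogen and nothing else differs. Within the data shown here, no measured pair isolates this exchange, so the data give no size for it. With nothing pointing either way, no step beyond the scatter is expected in this assay and no direction is favoured. The expectation is anchored on compound 1 at 85100 nM as the measured compound that differs from compound 3 in this one place. The expected size is a 1.1-fold lower number from compound 1 to compound 3 (0.03 log units; within the scatter) and so stays within the scatter. In this assay compound 3 is therefore estimated at 80000 nM with a range from 35000 nM to 180000 nM as the expected span of a measurement.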

Compound 3, half-maximal inhibitory concentration: > 100000 nM
Compound 3 was reported as a limit (the forecaster's own chance of this, stated with the estimate: 25%); middle value at least 1.2-fold (0.09 log units) from the limit.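

In this assay compound 3 gives > 100000 nM, which is a limit of the assay and not a number. Among these compounds, on the amide-type nitrogen, the exchange of the group of 11 heavy atoms for cyclohexyl gives an at least 1.1-fold higher number from compound 1 to compound 3 (0.07 log units; that floor lies within the scatter), the first reading for this place, and it shows no stronger inhibition with the all-carbon ring. How far the step goes past that floor cannot be read, because the reading stops at the end of the assay's range: the limit of > 100000 nM in this assay, at which 1 of the 3 values shown sits.

From the compounds shown here alone, what remains open is how this place responds to groups that could give a number clear of the limit, such as a piperidine ring with a free nitrogen, a cyclohexyl ring carrying a hydroxyl or an amine, or an open butyl chain. Whether the ring atoms that distinguish the group in compound 1 from cyclohexyl matter at all also stays unsettled, since the values at hand sit near the top of the range and a single exchange on this nitrogen gives only a floor.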